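The source may report more compounds than this note shows. Statements on the series, on what has been measured and on what is new or still open speak of the compounds shown alone.

In a functional assay on HeLa cells (Homo sapiens) for inhibition, read by CCK-8 assay, with a stated time of 72 h, tested at 2 uM (a lower number here means less inhibition of growth, a higher number more inhibition of growth at the concentration tested), compound 1 `Nc1ccccc1NC(=O)c1ccc(CSc2cccc(F)c2)cc1` gives 22.5% and compound 2 `Nc1ccccc1NC(=O)c1ccc(CSCCc2ccccc2)cc1` gives 27.7%, so compound 2 stands level with compound 1 within the scatter. Compound 3 `Cc1cc(C)cc(SCc2ccc(C(=O)Nc3ccccc3N)cc2)c1` differs from compound 2 as follows: 3,5-dimethylphenyl in place of phenethyl on a sulfur. This places 3,5-dimethylphenyl in place of phenethyl on a sulfur. Going by the values given here, the only measured step that bears on this change is a number 5.2 percentage points higher from compound 1 to compound 2 (within the scatter), which exchanged 3-fluorophenyl and phenethyl on a sulfur and stayed within the scatter. The expected a number 2.7 percentage points lower from compound 2 to compound 3 (within the scatter) is therefore small, with no shift beyond the scatter in either direction. Compound 3 is estimated at 25%, within a range of 13% to 40%.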

Compound 3, percent growth inhibition at one concentration: 40.2%
The estimate for compound 3 lay 15.2 percentage points below the measured number; the measured number lies above the stated range.
By their numbers in this assay, from the lowest: compounds 1 and 2 (each within the scatter of the next); then compound 3.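

In this assay, the group on the sulfur now shifts the number beyond the scatter, which the earlier pair did not show: 3,5-dimethylphenyl in place of phenethyl gives a number 12.5 percentage points higher from compound 2 to compound 3 (beyond the scatter) and in place of 3-fluorophenyl gives a number 17.7 percentage points higher from compound 1 to compound 3 (beyond the scatter). Phenethyl and 3,5-dimethylphenyl have the same atoms and each holds one six-membered aromatic ring, so these counts do not separate compound 2 from compound 3. Nothing available here explains the higher number. The compounds shown leave open whether both methyl groups are needed, and how a plain phenyl, a 3,5-dichlorophenyl or a 3,5-dimethoxyphenyl on the sulfur would compare.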